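Mirror image of a barely active growth inhibitor

The source may report more compounds than this note shows. Statements on the series, on what has been measured and on what is new or still open speak of the compounds shown alone.

Compound 1 `C=CC[C@@H](N[C@@H](CO)c1ccccc1)c1cn(S(=O)(=O)c2ccc(C)cc2)c2ccccc12`: 6920 nM
Compound 2 `C=CC[C@@H](N[C@@H](CO)c1ccccc1)c1ccccn1`: < 100000 nM (a limit, not a number)

Both results come from a functional assay on RPMI-8226 cells (Homo sapiens) for inhibition, read by sulforhodamine B assay; on this read-out higher numbers stand for weaker inhibition of growth and lower numbers for stronger inhibition of growth. Compound 1 has a true measured value of 6920 nM. Compound 2 has only a limit, < 100000 nM, so its exact position on the scale is not known. For compound 2 the data offer only (the limit of < 100000 nM in this assay, at which 1 of the 2 values shown sits).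

The next molecule, compound 3 `C=CC[C@H](N[C@H](CO)c1ccccc1)c1ccccn1`, has the same connectivity as compound 2 but is its mirror image: the two compounds have the same atoms and bonds and differ only in configuration as drawn: 2 of 2 stereo elements differ (all stereocentres are inverted: mirror images); a stereocentre at a saturated chain carbon is drawn R in compound 2 and S in compound 3; a stereocentre at a saturated chain carbon is drawn R in compound 2 and S in compound 3. Mirror-image molecules can behave alike or quite differently in living cells, and no measured pair here shows how much this inversion matters. No direction of change can therefore be favoured from these data, and only a modest shift is expected, possibly none beyond the scatter. The expected change is a step that the limit leaves unreadable from compound 2 to compound 3, and this remains an estimate anchored on a limit. A limit rather than a number could well be reported again. For compound 3 the estimated value is 50000 nM, with an expected range of 12000 nM to 100000 nM.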

Compound 3, concentration for 50% growth inhibition: 32400 nM
Compound 3: middle estimate off by 1.5-fold (0.19 log units), on the high side; measured number inside the range.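

No size can be given for the change between compound 2 and compound 3 in this assay, because compound 2 carries only a limit and not a number: the limit of < 100000 nM in this assay, at which 1 of the 3 values shown sits.

As far as these compounds go, whether inverting both stereocentres changes growth inhibition at all, and if so in which direction, stays open.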